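From methyl to cyano: the next step for compound 3

The source may report more compounds than this note shows. Statements on the series, on what has been measured and on what is new or still open speak of the compounds shown alone.

Two compounds have been measured so far in a functional assay on K562 cells (Homo sapiens) for antiproliferative activity, read by MTT assay, with a stated time of 48 h; a lower number here means a stronger inhibitor, a higher number a weaker inhibitor:
compound 1 `COc1ccc(CN2C(=O)C(=O)c3cc(-c4ccc(C(C)(C)C)cc4)ccc32)cc1` gives 2250 nM
compound 2 `COc1ccc(CN2C(=O)C(=O)c3cc(-c4ccc(C)cc4)ccc32)cc1` gives 400 nM

Compound 2 stands lowest of these two numbers; its nearest neighbour is compound 1, separated by the step of a 5.6-fold lower number from compound 1 to compound 2 (0.75 log units; beyond the scatter), which lies beyond the usual scatter. The next compound, compound 3 `COc1ccc(CN2C(=O)C(=O)c3cc(-c4ccc(C#N)cc4)ccc32)cc1`, differs from compound 2 by cyano in place of methyl on an aromatic carbon. For the measured compounds named here, the only measured step, in which methyl replaced tert-butyl on an aromatic carbon, bears on this change merely by showing that the group at this place can move the number noticeably. Going by the values given here, no measured step involves a cyano group, so the direction of this change cannot be read from the data at hand. The expected size of the step is therefore a 1.3-fold higher number from compound 2 to compound 3 (0.10 log units; within the scatter), with a modest shift in either direction remaining plausible. Compound 3 is estimated at 500 nM, within 150 nM to 1700 nM.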

Compound 3, half-maximal inhibitory concentration: 260 nM
Compound 3: the middle estimate sits 1.9-fold (0.28 log units) above what was measured; measured number inside the range.
By their numbers in this assay, from the lowest: compounds 3 and 2 (each within the scatter of the next); then compound 1.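

In this assay, putting cyano in place of methyl on this aromatic carbon gives a 1.5-fold lower number from compound 2 to compound 3 (0.19 log units; within the scatter) and so does not separate the two groups, although cyano adds a nitrogen and a hydrogen-bond acceptor. Cyano in place of tert-butyl gives an 8.7-fold lower number from compound 1 to compound 3 (0.94 log units; beyond the scatter) and is the second replacement of tert-butyl to lower the number beyond the scatter, leaving compound 1 apart from both compound 2 and compound 3. No supporting measurement is available to explain these differences.

On these data alone, whether an amine, a carboxylic acid or a longer chain at this place would fall with methyl and cyano or with tert-butyl remains open. As far as these compounds go, it is also open whether these same swaps would give similar steps with a different group elsewhere on the shared core.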